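The source may report more compounds than this note shows. Statements on the series, on what has been measured and on what is new or still open speak of the compounds shown alone.

In a functional assay on CEM-DNR-bulk cells (Homo sapiens), read by MTT assay, with a stated time of 72 h (a higher number here means a weaker inhibitor, a lower number a stronger inhibitor), compound 1 `C#Cc1cn([C@@H]2O[C@H](CO)[C@@H](O)[C@H]2O)c2ncnc(C)c12` gives 160 nM as a measured number. Compound 2 `COc1nc(N)nc2c1c(-c1ccoc1)cn2[C@@H]1O[C@H](CO)[C@@H](O)[C@H]1O` reads > 20000 nM and this is a limit of the assay, not a number. Only compound 1 therefore offers a measured potency. Compound 3 `COc1nc(N)nc2c1c(-c1cc3ccccc3o1)cn2[C@@H]1O[C@H](CO)[C@@H](O)[C@H]1O` keeps the core of compound 2 and carries 1-benzofuran-2-yl in place of furan-3-yl on an aromatic carbon of the five-membered aromatic ring with 1 nitrogen (1-benzofuran-2-yl in place of furan-3-yl on an aromatic carbon). Among the compounds with values here, no measured pair shows what such a change does. With compound 2 at > 20000 nM as its starting limit, no step beyond the scatter is expected in this assay and compound 3 may well report a limit too. The expected change is a number no higher from compound 2 to compound 3 (the limit leaves the size open) as an estimate. For compound 3 the estimated value is 20000 nM with an expected range from 6000 nM to 40000 nM in this assay.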

Compound 3, half-maximal inhibitory concentration: 16700 nM
Estimate against measurement, compound 3: 1.2-fold (0.08 log units) above, within the range that was stated.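

With 1-benzofuran-2-yl in place of furan-3-yl on this aromatic carbon, the position gives its first measured number in this assay: compound 3 reads 16700 nM. The change can be read only as an at least 1.1-fold lower number from compound 2 to compound 3 (0.07 log units; that floor lies within the scatter), so the result sets a floor for the step and does not give its size. The reading of compound 2 remains a limit of the assay and not a number, and that limit is what leaves the size open: the limit of > 20000 nM in this assay, at which 1 of the 3 values shown sits.

The compounds shown leave open how an amine, a carboxylic acid or a longer chain on this aromatic carbon would read in this assay. Compound 1 differs from compound 3 in more than one place, so its value cannot be set against this change.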